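This account rests on a few compounds, and the source may have more. Where it says the series, first, only, none or still open, it means among the compounds named here.

- compound 1 `Cc1ccc(-c2cc(-c3ccoc3)cc(-c3ccc(Cl)s3)n2)o1`: 26500 nM
- compound 2 `Cc1ccc(-c2cc(-c3ccoc3)cc(-c3ccc(Cl)s3)n2)cc1`: 28700 nM
- compound 3 `Clc1cccc(-c2cc(-c3ccoc3)cc(-c3ccc(Cl)s3)n2)c1`: 23700 nM

All three values come from a functional assay on HeLa cells (Homo sapiens) for cytotoxicity, read by ELISA, with a stated time of 4 days (a lower number here means a stronger inhibitor, a higher number a weaker inhibitor), and the compounds differ only in one aromatic group on the shared core. Compound 3 stands level with the other two, since its values cannot be told apart from theirs: a 1.1-fold lower number from compound 1 to compound 3 (0.05 log units; within the scatter) and a 1.2-fold lower number from compound 2 to compound 3 (0.08 log units; within the scatter) both fall within the scatter.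

The next compound to consider is compound 4 `Clc1ccc(-c2cc(-c3ccoc3)cc(-c3ccc(Cl)s3)n2)cc1`. It has 4-chlorophenyl in place of 3-chlorophenyl on an aromatic carbon, so the same atoms are joined differently.

For the measured compounds named here, no measured pair isolates this kind of change, so the evidence is indirect. The nearest guide is a 1.2-fold lower number from compound 2 to compound 3 (0.08 log units; within the scatter), where the group at the same place was exchanged. In addition, a 1.1-fold higher number from compound 1 to compound 2 (0.03 log units; within the scatter) and a 1.1-fold lower number from compound 1 to compound 3 (0.05 log units; within the scatter) replace a 5-methylfuran-2-yl group at that place. Each of these larger exchanges left the number within the scatter, so a smaller change to the same group is not expected to do more in this assay. No direction can be favoured. The expected change is a 1.1-fold higher number from compound 3 to compound 4 (0.02 log units; within the scatter), which would stay within the scatter. For compound 4, the estimated value is 25000 nM, with an expected range from 14000 nM to 43000 nM.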

Compound 4, half-maximal inhibitory concentration: 16500 nM
The estimate for compound 4 lay 1.5-fold (0.18 log units) above the measured number, within the range that was stated.
By their numbers in this assay, from the lowest: compounds 4, 3, 1 and 2 (each within the scatter of the next).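

For the compounds shown here, compound 4 gives the first look at whether the position of the chlorine on the phenyl ring matters at this place, next to the ring nitrogen, and in this assay moving it from 3-chlorophenyl to 4-chlorophenyl gives a step that stays within the scatter (a 1.4-fold lower number from compound 3 to compound 4 (0.16 log units; within the scatter)). Going by these compounds alone, the same holds for the first direct exchange of chloro for methyl on the phenyl ring (a 1.7-fold lower number from compound 2 to compound 4 (0.24 log units; within the scatter)) and for the exchange of 5-methylfuran-2-yl for 4-chlorophenyl (a 1.6-fold lower number from compound 1 to compound 4 (0.21 log units; within the scatter)), so all four groups at this place give numbers that cannot be told apart with confidence. No measurement is available that could explain this flat picture.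

As far as these compounds go, all four compounds keep the furan-3-yl and 5-chlorothiophen-2-yl groups, so what those two places contribute remains open. From the compounds shown here alone, it also remains open whether an amine, a carboxylic acid or a longer chain on the phenyl ring would carry the number in this assay beyond the scatter.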